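Working notes: ring-nitrogen substituent, compound 3 to compound 4

The source may report more compounds than this note shows. Statements on the series, on what has been measured and on what is new or still open speak of the compounds shown alone.

Compound 3 `Cn1c(=O)c(-c2cccc([N+](=O)[O-])c2)nc2ccccc21` carries a methyl on the ring nitrogen and a nitrophenyl on the shared core. In an assay on cells for activation of Cystic fibrosis transmembrane conductance regulator (Homo sapiens), read by fluorescence, with a stated time of 10 min (a higher number here means that more compound is needed for the effect, a lower number that less compound is needed), compound 3 gives only a limit, > 10000 nM. Compound 2 `Cc1cc2nc(-c3cccc([N+](=O)[O-])c3)c(=O)n(Cc3ccccc3)c2cc1C` also stops at a limit in this assay, > 10000 nM. Compound 1 `O=c1c(-c2cccc(Br)c2)nc2ccccc2n1Cc1ccccc1`, with a benzyl on the ring nitrogen and a bromophenyl, gives 330 nM in this assay. Compound 3 therefore stands at the limit of > 10000 nM in this assay, at which 2 of the 3 values shown sit, with no number of its own.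

Compound 4 `O=c1c(-c2cccc([N+](=O)[O-])c2)nc2ccccc2n1Cc1cccs1` differs from compound 3 by thiophen-2-yl in place of hydrogen on a saturated chain carbon bound to an aromatic nitrogen. Among the compounds with values here, no measured pair shows this change. Compound 1 pairs a larger group on the ring nitrogen with a measured number, while compound 2 pairs a benzyl with the nitrophenyl that compound 4 keeps and reaches no number. The expected step, an at least 1.6-fold lower number from compound 3 to compound 4 (0.22 log units; that floor lies within the scatter), is estimated to run toward less compound needed, but only modestly and with a real chance of another limit. Compound 4 is expected to give about 6000 nM in this assay, between 1500 nM and 20000 nM.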

Compound 4, half-maximal effective concentration: 10 nM
Compound 4: middle estimate off by 600-fold (2.78 log units), on the high side, and the stated range ends above it.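

Thiophen-2-yl in place of hydrogen on a saturated chain carbon bound to an aromatic nitrogen gives an at least 1000-fold lower number from compound 3 to compound 4 (3.00 log units; beyond the scatter) in this assay, the first step in the series read between compounds differing in one place. With the nitrophenyl kept, this change alone moves the series from a limit to a measured number, so the nitrophenyl does not by itself hold a compound at the limit. Compound 3 gives only a limit, so the step is a floor and its full size stays unknown: the limit of > 10000 nM in this assay, at which 2 of the 4 values shown sit.

Whether the change depends on thiophen-2-yl or on any aromatic ring at this place stays open, as no pair shown sets benzyl against (thiophen-2-yl)methyl with all else equal. The compounds shown also leave open how furan-2-yl, an amine or a longer chain would read there.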